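Swapping Fluoro for Chloro on the Amide Aryl Ring

This account rests on a few compounds, and the source may have more. Where it says the series, first, only, none or still open, it means among the compounds named here.

Compound 1 `CC1=C(C(=O)Nc2ccc(F)c(Cl)c2)C(c2ccccc2Cl)NC(=S)N1`: 20400 nM
Compound 2 `CC1=C(C(=O)Nc2ccc(F)c(Cl)c2)C(c2cccc(Oc3ccccc3)c2)NC(=S)N1`: 12000 nM
Compound 3 `CC1=C(C(=O)Nc2ccc(Cl)c(Cl)c2)C(c2cccc(Oc3ccccc3)c2)NC(=S)N1`: 9770 nM

Of the compounds shown here, three have been measured in a functional assay on PC-3 cells (Homo sapiens) for cytotoxicity, read by sulforhodamine B assay, with a stated time of 48 h; a higher number here means a weaker inhibitor of growth, a lower number a stronger inhibitor of growth. Compound 1 has the highest of the three numbers. Its nearest neighbour is compound 2, and the gap between those two lies within the usual scatter. The gap from compound 1 to compound 3 is a little beyond the scatter. Compound 2 and compound 3 share one core, and compound 1 is built on a different one; how the two cores differ is not broken down here.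

Compound 2 and compound 3 differ in one place, (chloro in place of fluoro on an aromatic carbon). That change gave a 1.2-fold lower number from compound 2 to compound 3 (0.09 log units; within the scatter), a step too small to count as a real difference.

Compound 4 `CC1=C(C(=O)Nc2ccc(Cl)c(Cl)c2)C(c2ccccc2Cl)NC(=S)N1` has not yet been measured. It stands to compound 1 as compound 3 stands to compound 2: the change is chloro in place of fluoro on an aromatic carbon. The place of the change is described in the same words in both pairs, so it is the same change made on the other core.

Among the measured compounds shown here, with only one measured example of this change, and that one within the scatter, the expectation is that compound 4 will sit close to compound 1 in this assay, with the step estimated at a 1.2-fold lower number from compound 1 to compound 4 (0.08 log units; within the scatter), because the matching step was a 1.2-fold lower number from compound 2 to compound 3 (0.09 log units; within the scatter). Compound 4 is therefore expected to give about 17000 nM, within a range from 8500 nM to 34000 nM.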

Compound 4, concentration for 50% growth inhibition: 20000 nM
For compound 4 the middle estimate is 1.2-fold (0.07 log units) below the measured one; low and high end bracket the measured number.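

In this assay, replacing the fluoro of the 3-chloro-4-fluorophenyl group with chloro, which gives the 3,4-dichlorophenyl group, produced a 1.0-fold lower number from compound 1 to compound 4 (0.01 log units; within the scatter). Set beside the earlier example of the same swap, the result on the core of compound 1 cannot be told apart from the result on the other core: the same change on two cores in this assay, a 1.2-fold lower number (0.09 log units; within the scatter) from compound 2 to compound 3 and a 1.0-fold lower number (0.01 log units; within the scatter) from compound 1 to compound 4, 1.2-fold (0.08 log units) apart, within the scatter of two such steps. This shows that, on these two cores, the swap gave no step larger than the scatter, but the agreement is only between two steps too small to count as real differences, so it does not show that a change of real size would carry from one core to the other, and two pairs make no rule for the whole series.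

The compounds shown leave open what happens when a different group, such as a methoxy group, a nitrile or an amine, takes the place of the fluoro or chloro on this aromatic carbon. They also leave open whether the swap would again give so small a step on a third core, or in any test other than this assay.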